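The compounds below may be only part of what the source reports. "The series", "measured", "known", "first", "only" and "open" are said of these compounds alone.

Compound 2 `O=c1ccc2cc(OCc3cc(-c4cccc(Cl)c4)no3)ccc2o1` carries a 3-chlorophenyl group on the five-membered ring of the shared core. In a functional assay on PC-3 cells (Homo sapiens) for cytotoxicity, read by MTT assay, with a stated time of 48 h (on this read-out lower numbers stand for stronger inhibition and higher numbers for weaker inhibition), compound 2 gives "not determined" (no result reported), so it offers no number to start from. The related compound 1 `O=c1ccc2cc(OCc3cc(-c4cccc5ccccc45)no3)ccc2o1` likewise gives "not determined" (no result reported) in this assay. Among the measured compounds shown here, the only reported number comes from compound 3 `N#Cc1ccccc1-c1cc(COc2ccc3oc(=O)ccc3c2)on1`, which in this assay gives 13600 nM, a weak result. Compound 4 `COc1ccccc1-c1cc(COc2ccc3oc(=O)ccc3c2)on1` arises from compound 2 by the change (2-methoxyphenyl in place of 3-chlorophenyl on an aromatic carbon). For the measured compounds named here, with no measured step between these two compounds, the size and direction of the change cannot be read from the data; the expectation rests on compound 3 alone. Compound 4 is therefore expected to give 15000 nM in this assay, within a range from 4000 nM to 60000 nM.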

Compound 4, half-maximal inhibitory concentration: 22400 nM
Compound 4: middle estimate off by 1.5-fold (0.17 log units), on the low side; measured number inside the range.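

In this assay, methoxy in place of cyano on an aromatic carbon gives a 1.6-fold higher number from compound 3 to compound 4 (0.22 log units; within the scatter). Among the compounds shown here, two different groups on the phenyl ring at this position, the only two here with numbers, therefore cannot be told apart on this read-out. No measurement at hand explains this result. Steps from compound 1 or compound 2 cannot be read, so the 3-chlorophenyl group cannot be compared with the others. From the compounds shown here alone, whether an amine or a carboxylic acid in place of methoxy would give a number beyond the scatter remains open.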